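This account rests on a few compounds, and the source may have more. Where it says the series, first, only, none or still open, it means among the compounds named here.

In a functional assay, read by spectrophotometry, tested at 100 uM (on this read-out lower numbers stand for stronger inhibition and higher numbers for weaker inhibition), compound 1 `COc1ccc(/C=C/C(=O)c2cccc(NC(=O)c3cc(-c4ccncc4)n[nH]3)c2)cc1` gives 54600 nM and compound 2 `COc1cc(/C=C/C(=O)c2cccc(NC(=O)c3cc(-c4ccncc4)n[nH]3)c2)cc(OC)c1OC` gives 52900 nM, so these two cannot be told apart within the usual scatter. Compound 3 `O=C(/C=C/c1ccc(Cl)cc1Cl)c1cccc(NC(=O)c2cc(-c3ccncc3)n[nH]2)c1`, not yet measured, carries 2,4-dichlorophenyl in place of 3,4,5-trimethoxyphenyl on a double-bonded chain carbon bound to a double-bonded chain carbon. For the measured compounds named here, only one measured step bears on this place, a 1.0-fold lower number from compound 1 to compound 2 (0.01 log units; within the scatter), and it stayed within the scatter. Going by the values given here, no measured compound here carries chlorine, so that step is a thin guide, and no shift beyond the scatter is expected in this assay. The expected change is a 1.2-fold lower number from compound 2 to compound 3 (0.07 log units; within the scatter). For compound 3 the estimate is 45000 nM, with a range from 18000 nM to 100000 nM.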

Compound 3, half-maximal inhibitory concentration: 80900 nM
Compound 3: the middle estimate sits 1.8-fold (0.25 log units) below what was measured, and the stated range covers the measured number.
By their numbers in this assay, from the lowest: compounds 2, 1 and 3 (each within the scatter of the next).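

In this assay the 2,4-dichlorophenyl group gives a 1.5-fold higher number from compound 2 to compound 3 (0.18 log units; within the scatter) and also a 1.5-fold higher number from compound 1 to compound 3 (0.17 log units; within the scatter) as the second step. Three differently substituted phenyl groups on a double-bonded chain carbon bound to a double-bonded chain carbon therefore cannot be told apart, whether the ring carries methoxy groups or chlorine atoms. Nothing measured here explains these numbers.

As far as these compounds go, whether a ring without a phenyl group, such as pyridine, or a chain ending in an amine would move the number beyond the scatter stays open. So does whether changes elsewhere in the shared core would matter more.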